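Heptyl in Place of Butoxy on the Shared Core

The source may report more compounds than this note shows. Statements on the series, on what has been measured and on what is new or still open speak of the compounds shown alone.

Measured in a functional assay on the whole organism with Rattus norvegicus as the target; on this read-out lower numbers stand for an effect already at smaller amounts and higher numbers for an effect only at larger amounts of compound:
compound 1 `CCCCc1ccc(-c2c(C)[nH]c(=O)n2C)cc1` gives 0.1 mg/kg
compound 2 `CCCCOc1ccc(-c2c(C)[nH]c(=O)n2C)cc1` gives 0.3 mg/kg
compound 3 `Cc1[nH]c(=O)n(C)c1-c1ccc(C2CCCCC2)cc1` gives 0.1 mg/kg

Compound 2 holds the highest number of the three: a 3.0-fold higher number from compound 1 to compound 2 (0.48 log units; beyond the scatter) and a 3.0-fold lower number from compound 2 to compound 3 (0.48 log units; beyond the scatter), while no change at the digits printed from compound 1 to compound 3 (within the scatter). Compound 4 `CCCCCCCc1ccc(-c2c(C)[nH]c(=O)n2C)cc1` differs from compound 2 by heptyl in place of butoxy on an aromatic carbon. For the measured compounds named here, two measured steps bear on this change, a 3.0-fold higher number from compound 1 to compound 2 (0.48 log units; beyond the scatter) read in reverse and a 3.0-fold lower number from compound 2 to compound 3 (0.48 log units; beyond the scatter); both show that a group of carbon only in place of butoxy gave a modestly lower number. Heptyl is also a group of carbon only, but no measured step compares it with butyl or cyclohexyl. A modest lower number is therefore expected: a 2.0-fold lower number from compound 2 to compound 4 (0.30 log units; within the scatter). Compound 4 is estimated at 0.15 mg/kg, with a range from 0.04 mg/kg to 0.6 mg/kg.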

Compound 4, minimum effective dose: 30 mg/kg
Compound 4: middle estimate off by 200-fold (2.30 log units), on the low side, and the stated range ends below it.
By their numbers in this assay, from the lowest: compounds 1 and 3 (each within the scatter of the next); then compound 2; then compound 4.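

At this position a group of carbon only does not by itself keep the number low: in this assay, extending butyl to heptyl gives a 300-fold higher number from compound 1 to compound 4 (2.48 log units; beyond the scatter), although cyclohexyl and butyl showed no change. Heptyl also compares poorly with the other groups, with a 100-fold higher number from compound 2 to compound 4 (2.00 log units; beyond the scatter) and a 300-fold higher number from compound 3 to compound 4 (2.48 log units; beyond the scatter).

Nothing available explains this large jump. Pentyl and hexyl chains would test whether the number climbs gradually with chain length or jumps suddenly, and an amine at the end of the heptyl chain remains an open case.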